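A few compounds are considered here, and "the series" means these few. Any claim that something is new, unique, unknown or untested is made for them only; others in the source may bear on it.

Among the measured compounds shown here, in a functional assay on RKOp27 cells (Homo sapiens) for cytotoxicity, read by MTT assay, with a stated time of 3 days (on this read-out higher numbers stand for weaker inhibition and lower numbers for stronger inhibition), two compounds on a shared core have numbers so far. Compound 1 (`N#Cc1c(Nc2ccccc2)nc(SCc2nc3ccccc3[nH]2)nc1-c1ccccc1`) gives 4.9 nM and compound 2 (`N#Cc1c(Nc2ccccn2)nc(SCc2nc3ccccc3[nH]2)nc1-c1ccccc1`) gives 3.8 nM on the same read-out, so compound 2 stands within the scatter of compound 1. Compound 3 (`N#Cc1c(Nc2nccs2)nc(SCc2nc3ccccc3[nH]2)nc1-c1ccccc1`) differs from compound 2 in one place, and the change (1,3-thiazol-2-yl in place of pyridin-2-yl on a nitrogen on an aromatic ring) puts 1,3-thiazol-2-yl in place of pyridin-2-yl on a nitrogen on an aromatic ring. For the measured compounds named here, only one measured step bears on it, the exchange of phenyl for pyridin-2-yl at that same place. That step, a 1.3-fold lower number from compound 1 to compound 2 (0.11 log units; within the scatter) in size, is small. On the evidence of compound 2 and this step, a further exchange of aromatic ring on the nitrogen is expected to stay within the scatter, in neither direction. Going by the values given here, one step is thin evidence, and no five-membered ring has yet been measured at this place. The step expected is a 1.2-fold higher number from compound 2 to compound 3 (0.07 log units; within the scatter) and no larger change is estimated. For compound 3 the estimated value in this assay is 4.5 nM with an expected range of 1.8 nM to 11 nM once it is measured.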

Compound 3, half-maximal inhibitory concentration: 3.2 nM
Estimate against measurement, compound 3: 1.4-fold (0.15 log units) above; the range from low to high includes it.
By their numbers in this assay, from the lowest: compounds 3, 2 and 1 (each within the scatter of the next).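

In this assay, the first five-membered aromatic ring at this place, 1,3-thiazol-2-yl on a nitrogen on an aromatic ring, brings a 1.2-fold lower number from compound 2 to compound 3 (0.07 log units; within the scatter), and measured against the phenyl group it brings a 1.5-fold lower number from compound 1 to compound 3 (0.19 log units; within the scatter). The place on the nitrogen therefore accepts not only an exchange between six-membered aromatic rings but also a change of ring size and the entry of a sulfur atom, and phenyl, pyridin-2-yl and 1,3-thiazol-2-yl cannot be told apart on this read-out, all three compounds staying in the low nanomolar range. Nothing available accounts for this flat result or shows what the three groups have in common that matters here.

On these data alone, all three groups are aromatic rings without further substituents, so it remains open whether a saturated ring such as morpholine, a plain ethyl or longer alkyl chain, or a phenyl ring carrying an amine or a carboxylic acid would keep the number in this range. The rest of the shared core is the same throughout, so these compounds also say nothing about the nitrile, or about an amide in its place.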